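The source may hold more compounds than are shown below. What is called first, only, known or untested is meant among the compounds shown, and "the series" means these compounds.

Compound 2 `CCOC(=O)CCCCCOc1cccc(CN(C(=O)c2ccc(-c3cccc(OC)c3)cc2)C(C)C)c1` stands at the edge of what can be measured: in an ADME assay on HEK293 cells (Homo sapiens) for cytotoxicity, read by CellTiter-Glo and resazurin assay, with a stated time of 72 h (on this read-out lower numbers stand for an effect already at smaller amounts and higher numbers for an effect only at larger amounts of compound), compound 2 gives > 21000 nM, which is a limit of the assay and not a number. Compound 1 `CCOC(=O)CCCCCOc1cccc(CN(C(=O)c2ccc(-c3cccc(-c4nnc(C)o4)c3)cc2)C(C)C)c1` also reaches only a limit, giving > 26000 nM in this assay. Among the measured compounds shown here, the one measured step, a step that the two limits leave unreadable from compound 1 to compound 2, cannot be read because the limit of > 21000 nM in this assay, at which 1 of the 2 values shown sits, and the limit of > 26000 nM in this assay, at which 1 of the 2 values shown sits, both sit at the edge of the assay, so its size remains unknown.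

Compound 3 `CCOC(=O)CCCCCOc1cccc(CN(C(=O)c2ccc(-c3ccc(Cl)c(Cl)c3)cc2)C(C)C)c1` differs from compound 2 by 3,4-dichlorophenyl in place of 3-methoxyphenyl on an aromatic carbon. For the measured compounds named here, with both neighbours at limits, no measured step points in either direction, so no movement beyond the scatter is expected, and the step that the limit leaves unreadable from compound 2 to compound 3 is only an estimate of no change. Compound 3 is therefore expected to give about 25000 nM in this assay, most likely again as a limit, with a range from 8000 nM to 80000 nM.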

Compound 3, half-maximal effective concentration: > 26000 nM
Compound 3 gave a limit, no number; the forecaster's own chance of this, stated with the estimate: 70%; middle value at least 1.0-fold (0.01 log units) away from the limit.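

Compound 3 also gives only a limit, so the steps to it from compound 1 and compound 2 cannot be read. The compounds shown leave open at what concentration any of them has an effect in this assay, and whether these group exchanges change it.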